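Ethyl to Isopropyl Ester in a Small Adenosine Series

The source may report more compounds than this note shows. Statements on the series, on what has been measured and on what is new or still open speak of the compounds shown alone.

Four compounds share one core and were compared in an assay on HeLa cells for displacement of a labelled ligand from adenosine receptor A3 (Homo sapiens), with a stated time of 180 min, tested at 10 uM; a higher number here means more inhibition at the concentration tested (going by the name of the read-out), a lower number less inhibition. Compound 1 `CC1=C(C(=O)OC(C)C)C(c2ccco2)NC(=O)N1C` gives 18%, and compound 2 `CC1=C(C(=O)OC(C)C)C(c2cccs2)NC(=O)N1C` gives 18%. The step of no change at the digits printed from compound 1 to compound 2 (within the scatter) shows that swapping one five-membered aromatic ring for another leaves the read-out unchanged. Compound 3 `CCOC(=O)C1=C(C)N(C)C(=O)NC1c1ccoc1` gives 1%, the lowest of the three numbers, and it stands beyond the scatter below both compound 1 and compound 2.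

Compound 4 `CC1=C(C(=O)OC(C)C)C(c2ccoc2)NC(=O)N1C` is not yet measured. It differs from compound 3 in one place: methyl in place of hydrogen on a saturated chain carbon bound to an oxygen next to a carbonyl group and a saturated chain carbon. Among the measured compounds shown here, no measured step isolates this ester change. Compound 1 and compound 2 both carry the isopropyl ester and both sit well above compound 3, but each of them differs from compound 3 in a second place as well, so the ester alone cannot be credited with that gap. What the numbers do show is that the only ethyl ester in the set has the lowest inhibition in this assay, which leaves room for a modest rise.

For compound 4 the expected value in this assay is 10%, within a range of 0% to 25%. For the measured compounds named here, this expectation means a step of a number 9 percentage points higher from compound 3 to compound 4 (within the scatter), small and uncertain, given that no measured pair tests this change directly.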

Compound 4, a percentage reported as inhibition, at one concentration (the size of the read-out at that concentration, not a potency): 1%
Estimate against measurement, compound 4: 9 percentage points above, within the range that was stated.
By their numbers in this assay, from the lowest: compounds 3 and 4 (each within the scatter of the next); then compounds 1 and 2 (each within the scatter of the next).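

Going from ethoxycarbonyl to isopropoxycarbonyl gives no change at the digits printed from compound 3 to compound 4 (within the scatter) in this assay, the first direct reading of this change, and with furan-3-yl on the saturated ring carbon the larger ester brings no gain. With the isopropyl ester held constant, the ring on that carbon does make a difference: furan-3-yl in place of thiophen-2-yl gives a number 17 percentage points lower from compound 2 to compound 4 (beyond the scatter) and furan-3-yl in place of furan-2-yl gives a number 17 percentage points lower from compound 1 to compound 4 (beyond the scatter) in this assay, so among these compounds the isopropyl ester alone does not go with the higher readings. Nothing available here offers an explanation for these steps.

Still open, on these data alone, is whether the change from ethyl to isopropyl would read the same with furan-2-yl or thiophen-2-yl on the saturated ring carbon, since only the furan-3-yl pair tests it. Also open, as far as these compounds go, is how the read-out would respond to a phenyl ring on that carbon, or to a carboxylic acid in place of the ester.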